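This account rests on a few compounds, and the source may have more. Where it says the series, first, only, none or still open, it means among the compounds named here.

Compound 3 `Fc1ccc(Cc2ccc3c(NCCCNCc4ccco4)ccnc3c2)c(Cl)c1` stands lowest of the three numbers obtained in an ADME assay for permeability, using PAMPA, with a stated time of 30 min, at pH 7.4 (on this read-out lower numbers stand for lower permeability and higher numbers for higher permeability), where compound 3 gives 23 10^-6 cm/s. Compound 1 `COc1ccccc1Oc1ccc2c(NCCCNCc3ccco3)ccnc2c1` gives 317 10^-6 cm/s in this assay, and compound 2 `c1ccc(Oc2ccc3c(NCCCNCc4ccco4)ccnc3c2)cc1` gives 317 10^-6 cm/s. The step of a 14-fold lower number from compound 1 to compound 3 (1.14 log units; beyond the scatter) is large, as is the step of a 14-fold lower number from compound 2 to compound 3 (1.14 log units; beyond the scatter), while no change at the digits printed from compound 1 to compound 2 (within the scatter) shows that removing the methoxy group leaves the number where it was.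

Compound 4 `Cc1cc(C)cc(Cc2ccc3c(NCCCNCc4ccco4)ccnc3c2)c1` differs from compound 3 in one place: 3,5-dimethylphenyl in place of 2-chloro-4-fluorophenyl on a saturated chain carbon bound to an aromatic carbon. Among the compounds with values here, none of the measured steps exchanges one aromatic group for another on the saturated chain carbon; the two large steps both replace a phenoxy or 2-methoxyphenoxy group by 2-chloro-4-fluorobenzyl, and compound 4 keeps that benzyl arrangement, merely with 3,5-dimethylphenyl in place of 2-chloro-4-fluorophenyl. Within the data shown here, the only step that leaves the linkage untouched and alters only what sits on the aromatic ring is the one from compound 1 to compound 2, and it lies within the scatter. On that basis no step beyond the scatter is expected in this assay from compound 3 to compound 4, though the evidence is thin and the range is kept wide.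

Compound 4 is therefore estimated at 30 10^-6 cm/s, with a range from 10 10^-6 cm/s to 90 10^-6 cm/s. The expected step is a 1.3-fold higher number from compound 3 to compound 4 (0.12 log units; within the scatter).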

Compound 4, apparent permeability: 23 10^-6 cm/s
For compound 4 the middle estimate is 1.3-fold (0.12 log units) above the measured one; the measured number falls inside the stated range.
By their numbers in this assay, from the lowest: compounds 3 and 4 (each within the scatter of the next); then compounds 1 and 2 (each within the scatter of the next).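

In this assay, within the data shown here, the step of no change at the digits printed from compound 3 to compound 4 (within the scatter) comes from the first exchange of one aromatic group for another on a saturated chain carbon bound to an aromatic carbon, and it shows that 3,5-dimethylphenyl, all carbon, can stand in place of 2-chloro-4-fluorophenyl, with its fluorine and chlorine, without moving the number. The large gap is also no longer tied to one benzyl group, since the step of a 14-fold lower number from compound 2 to compound 4 (1.14 log units; beyond the scatter) and the step of a 14-fold lower number from compound 1 to compound 4 (1.14 log units; beyond the scatter) match those seen earlier for 2-chloro-4-fluorobenzyl, and among these four compounds none goes against the split between the two benzyl compounds and the two with phenoxy or 2-methoxyphenoxy. No measurement at hand gives a cause for this split or for the lack of change between the two benzyl groups.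

From the compounds shown here alone, what remains open is whether the split follows the linkage or the ring it carries, which a 3,5-dimethylphenoxy group on the same aromatic carbon would help to separate. Also open, going by these compounds, is how far the tolerance at the saturated chain carbon extends, for instance to a phenyl ring bearing an amine or a carboxylic acid, or to a longer chain.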